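The source may hold more compounds than are shown below. What is called first, only, known or untested is meant among the compounds shown, and "the series" means these compounds.

Measured compounds:
Compound 1 `CC(C)c1cccc(C(C)C)c1NC(=O)NCC1(c2ccccc2C(F)(F)F)CCCC1`: 18 nM
Compound 2 `CC(C)c1cccc(C(C)C)c1NC(=O)NCC1(c2ccc([N+](=O)[O-])cc2)CCCC1`: 131 nM
Compound 3 `CC(C)c1cccc(C(C)C)c1NC(=O)NCC1(c2cccc(N)c2)CCCC1`: 21 nM

In an assay on microsomes for inhibition of acyl-CoA:cholesterol acyltransferase (Oryctolagus cuniculus) (on this read-out lower numbers stand for stronger inhibition and higher numbers for weaker inhibition), compound 3 gives 21 nM, the second highest of the three numbers. The gap a 1.2-fold higher number from compound 1 to compound 3 (0.07 log units; within the scatter) is small, whereas a 6.2-fold lower number from compound 2 to compound 3 (0.80 log units; beyond the scatter) is a modest but real difference. Compound 4 `COC(=O)c1cccc(C2(CNC(=O)Nc3c(C(C)C)cccc3C(C)C)CCCC2)c1` carries methoxycarbonyl in place of amino on an aromatic carbon. The three measured steps all swap the group on the phenyl ring attached to the saturated ring, and only the nitro compound, seen through a 7.3-fold higher number from compound 1 to compound 2 (0.86 log units; beyond the scatter) and a 6.2-fold lower number from compound 2 to compound 3 (0.80 log units; beyond the scatter), moved the number beyond the scatter. An ester with two acceptors and no donor resembles that case more than the amino case, so a modest rise in the number is expected: a 2.4-fold higher number from compound 3 to compound 4 (0.38 log units; beyond the scatter). The estimate for compound 4 is 50 nM, within 15 nM to 160 nM.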

Compound 4, half-maximal inhibitory concentration: 34 nM
Compound 4: middle estimate off by 1.5-fold (0.17 log units), on the high side; the measured number falls inside the stated range.
By their numbers in this assay, from the lowest: compounds 1, 3 and 4 (each within the scatter of the next); then compound 2.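

In this assay the replacement of amino by methoxycarbonyl, a larger group with 0 hydrogen-bond donors, on this aromatic carbon stays within the scatter (a 1.6-fold higher number from compound 3 to compound 4 (0.21 log units; within the scatter)). Compound 4 also stays within the scatter of compound 1 (a 1.9-fold higher number from compound 1 to compound 4 (0.28 log units; within the scatter)), so this position accepts a group without the amino hydrogens. Compound 2 remains apart (a 3.9-fold lower number from compound 2 to compound 4 (0.59 log units; beyond the scatter)). No measurement here bears on why. Open, from the compounds shown here alone, is whether a carboxylic acid or a primary amide on this carbon would also stay within the scatter.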